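Swapping the Aryl Group on a Shared Core

The source may report more compounds than this note shows. Statements on the series, on what has been measured and on what is new or still open speak of the compounds shown alone.

Of the compounds shown here, three built on one shared core have been measured in an assay on microsomes for inhibition of acyl-CoA:cholesterol acyltransferase (Oryctolagus cuniculus); on this read-out higher numbers stand for weaker inhibition and lower numbers for stronger inhibition. Compound 1 `CC(C)c1ccc(C2(CNC(=O)Nc3c(C(C)C)cccc3C(C)C)CCCC2)cc1` gives 48 nM. Compound 2 `COc1ccc(C2(CNC(=O)Nc3c(C(C)C)cccc3C(C)C)CCCC2)cc1` gives 31 nM in this assay, and compound 3 `COC(=O)c1cccc(C2(CNC(=O)Nc3c(C(C)C)cccc3C(C)C)CCCC2)c1` gives 34 nM. The steps between them are small: a 1.5-fold lower number from compound 1 to compound 2 (0.19 log units; within the scatter), a 1.4-fold lower number from compound 1 to compound 3 (0.15 log units; within the scatter) and a 1.1-fold higher number from compound 2 to compound 3 (0.04 log units; within the scatter). Compound 3 therefore sits in the same band as compound 1 and compound 2, with no separation beyond the scatter between any pair of the three.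

Compound 4 `Cc1ccc(C2(CNC(=O)Nc3c(C(C)C)cccc3C(C)C)CCCC2)c(C)c1` has not yet been measured. It differs from compound 3 in one place: 2,4-dimethylphenyl in place of 3-(methoxycarbonyl)phenyl on a saturated ring carbon. The two measured steps that bear on this change are those that also exchange the aromatic group attached to the saturated ring carbon: a 1.4-fold lower number from compound 1 to compound 3 (0.15 log units; within the scatter) and a 1.1-fold higher number from compound 2 to compound 3 (0.04 log units; within the scatter). Neither exchange moved the number beyond the scatter, so a further exchange at the same place is expected to give a step of no more than the scatter, in either direction. Compound 4 is therefore estimated at 40 nM, with a range from 15 nM to 110 nM. Compound 4 is thus expected to show a 1.2-fold higher number from compound 3 to compound 4 (0.07 log units; within the scatter).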

Compound 4, half-maximal inhibitory concentration: 50 nM
Estimate against measurement, compound 4: 1.3-fold (0.10 log units) below; the measured number falls inside the stated range.
By their numbers in this assay, from the lowest: compounds 2, 3, 1 and 4 (each within the scatter of the next).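

Exchanging 3-(methoxycarbonyl)phenyl, which has 2 hydrogen-bond acceptors, for 2,4-dimethylphenyl, which has 0, gives a step within the scatter in this assay (a 1.5-fold higher number from compound 3 to compound 4 (0.17 log units; within the scatter)), so at this saturated ring carbon the number stays in the same band even when the entering group has no hydrogen-bond acceptors at all. The same group also stays within the scatter when it replaces 4-methoxyphenyl (a 1.6-fold higher number from compound 2 to compound 4 (0.21 log units; within the scatter)) or 4-isopropylphenyl (a 1.0-fold higher number from compound 1 to compound 4 (0.02 log units; within the scatter)), which extends the band to a fourth aromatic group and to a ring bearing two methyl groups. Nothing presented here explains why these exchanges leave the number within the scatter.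

The four compounds give no ranking of these aromatic groups, and they leave open how far this tolerance reaches, since all of them keep a six-membered aromatic ring of carbon only at this place. Whether a carboxylic acid or an amine on that ring, or a pyridine ring or a longer chain in its place, would stay in the same band remains an open question.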